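Methyl for methylsulfanyl: expected cytotoxicity step

The source may hold more compounds than are shown below. What is called first, only, known or untested is meant among the compounds shown, and "the series" means these compounds.

Measured so far:
compound 1 `CSc1ccc(/C=N/NC(=O)COc2cccc3ccccc23)cc1`: > 100 ug/mL
compound 2 `C/C(=N\NC(=O)COc1cccc2ccccc12)c1ccc(O)cc1`: 11.1 ug/mL

In an ADME assay on HEL cells (Homo sapiens) for cytotoxicity (a higher number here means that more compound is tolerated, a lower number that less compound is tolerated), compound 1 gives > 100 ug/mL, which is a limit of the assay and not a number (the limit of > 100 ug/mL in this assay, at which 1 of the 2 values shown sits). In this assay, among the measured compounds shown here, compound 2 gives 11.1 ug/mL; no single-change step connects compound 2 to compound 1. Compound 3 `Cc1ccc(/C=N/NC(=O)COc2cccc3ccccc23)cc1` differs from compound 1 by methyl in place of methylsulfanyl on an aromatic carbon. For the measured compounds named here, no measured step covers this change. The step of a number no higher from compound 1 to compound 3 (the limit leaves the size open) is expected to be none beyond the scatter, a limit being the likely outcome again because compound 1 already sits at the limit of > 100 ug/mL in this assay, at which 1 of the 2 values shown sits. Compound 3 is estimated at 100 ug/mL, from 40 ug/mL to 250 ug/mL.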

Compound 3, half-maximal cytotoxic concentration: 80.1 ug/mL
Estimate against measurement, compound 3: 1.2-fold (0.10 log units) above; measured number inside the range.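

On the aromatic carbon para to a large group, methyl gives a measured number in this assay: compound 3 gives 80.1 ug/mL. Compound 1 gives > 100 ug/mL, which is a limit and not a number. Methyl in place of methylsulfanyl gives an at least 1.2-fold lower number from compound 1 to compound 3 (0.09 log units; that floor lies within the scatter), and the full size of the step stays open because one end of it is a limit: the limit of > 100 ug/mL in this assay, at which 1 of the 3 values shown sits.

Open, on these data alone, is whether an amine, a carboxylic acid or a longer chain at this position would give a step beyond the scatter. Also open, as far as these compounds go, is whether a step of this size holds for this change on a core other than that of compound 1.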